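Methoxy for Hydrogen on the Aryl Ring: Two Cores Compared

A few compounds are considered here, and "the series" means these few. Any claim that something is new, unique, unknown or untested is made for them only; others in the source may bear on it.

Measured compounds:
- compound 1, `COc1ccc(-c2cc(=O)c3c(OC)c(OC)c(OC)c(OC)c3o2)c(OC)c1`: 15 ug/mL
- compound 2, `COc1cc(OC)c(-c2cc(=O)c3c(OC)c(OC)c(OC)c(OC)c3o2)cc1OC`: 13 ug/mL
- compound 3, `COc1ccc2c(c1)OC(OC)(c1ccccc1)C(O)(O)C2=O`: 20 ug/mL

In a functional assay on KB cells (Homo sapiens) for cytotoxicity (a higher number here means that more compound is needed for the effect, a lower number that less compound is needed), compound 1 gives 15 ug/mL and compound 2 gives 13 ug/mL. The two differ by methoxy in place of hydrogen on an aromatic carbon, and the step of a 1.2-fold lower number from compound 1 to compound 2 (0.06 log units; within the scatter) is within the scatter. Compound 3, whose core is built differently, gives 20 ug/mL in this assay; its nearest neighbour is compound 1, and all three values lie within the scatter of one another. The difference between the core of compound 3 and the core of compound 1 is not broken down here.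

Compound 4, `COc1ccc(C2(OC)Oc3cc(OC)ccc3C(=O)C2(O)O)cc1`, is not yet measured. It differs from compound 3 by methoxy in place of hydrogen on an aromatic carbon. Among the compounds with values here, this is the same kind of change as the one from compound 1 to compound 2: methoxy in place of hydrogen on an aromatic carbon. The surroundings differ, though: in compound 2 the new group sits ortho to a methoxy group, meta to a large group and para to a methoxy group, while in compound 4 it sits para to a large group on a ring that otherwise carries only hydrogen.

Because the measured step of a 1.2-fold lower number from compound 1 to compound 2 (0.06 log units; within the scatter) stayed within the scatter, the step from compound 3 to compound 4 is expected to be small as well, a 1.2-fold lower number from compound 3 to compound 4 (0.07 log units; within the scatter). The core is different, so this expectation rests on one pair only. Compound 4 is therefore estimated at 17 ug/mL in this assay. Its expected range runs from 8 ug/mL to 36 ug/mL.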

Compound 4, concentration for half-maximal effect: 2.8 ug/mL
For compound 4 the middle estimate is 6.1-fold (0.78 log units) above the measured one, and the stated range ends above it.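

In this assay, the change from phenyl to 4-methoxyphenyl gave a 7.1-fold lower number from compound 3 to compound 4 (0.85 log units; beyond the scatter), so the new methoxy group, para to a large group, clearly mattered on this core. Set beside the earlier case, the same replacement of hydrogen by methoxy on an aromatic carbon did not carry over in size from one core to the other: the same change on two cores in this assay, a 1.2-fold lower number (0.06 log units; within the scatter) from compound 1 to compound 2 and a 7.1-fold lower number (0.85 log units; beyond the scatter) from compound 3 to compound 4, 6.2-fold (0.79 log units) apart, beyond the scatter of two such steps. Within the data shown here, this shows that the small step seen on the core of compound 1 was no reliable guide to the step on the core of compound 3, but it does not show why, since each core contributes only a single pair and the new methoxy group has different surroundings in the two pairs, so the role of the core cannot be separated from that of the substitution pattern.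

The compounds shown leave open whether an ethoxy group, a chlorine atom or an amine in the same place on the phenyl ring of compound 3 would give a step like that of methoxy in this assay. They also leave open how the same change would behave on any third core, and so whether either measured step is the more typical one.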